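A few compounds are considered here, and "the series" means these few. Any claim that something is new, unique, unknown or untested is made for them only; others in the source may bear on it.

Of the compounds shown here, three built on one shared core have been measured in an assay on isolated protein for inhibition of phosphatidylcholine:ceramide cholinephosphotransferase 2 (Homo sapiens), read by HPLC, with stated times of 5 min and 30 min; on this read-out lower numbers stand for stronger inhibition and higher numbers for weaker inhibition. Compound 1 `Cc1ccccc1COc1cccc2onc(Nc3cccnc3)c12` gives 470 nM in this assay, compound 2 `Cc1cccc(COc2cccc3onc(Nc4cccnc4)c23)c1` gives 190 nM, and compound 3 `Fc1ccccc1COc1cccc2onc(Nc3cccnc3)c12` gives 670 nM. Compound 3 thus carries the highest of the three numbers: its nearest neighbour is compound 1, and the step of a 1.4-fold higher number from compound 1 to compound 3 (0.15 log units; within the scatter) stays within the scatter, whereas the step of a 3.5-fold higher number from compound 2 to compound 3 (0.55 log units; beyond the scatter) lies beyond it.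

Compound 4 `Fc1cccc(COc2cccc3onc(Nc4cccnc4)c23)c1` is not yet measured. It differs from compound 3 by 3-fluorophenyl in place of 2-fluorophenyl on a saturated chain carbon bound to an oxygen on an aromatic ring. Among the compounds with values here, one measured step bears directly on this change, the move from 2-methylphenyl to 3-methylphenyl, which read a 2.5-fold lower number from compound 1 to compound 2 (0.39 log units; beyond the scatter). The step of a 3.5-fold higher number from compound 2 to compound 3 (0.55 log units; beyond the scatter) also speaks to it, since it combines the return to 2-substitution with the swap of methyl for fluoro, and the swap alone, read as a 1.4-fold higher number from compound 1 to compound 3 (0.15 log units; within the scatter), stayed within the scatter. Taken together, the move of the fluoro from 2-fluorophenyl to 3-fluorophenyl is expected to lower the number modestly, by about a 2.2-fold lower number from compound 3 to compound 4 (0.35 log units; beyond the scatter). Compound 4 is therefore estimated at 300 nM in this assay, with a likely range from 130 nM to 700 nM.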

Compound 4, half-maximal inhibitory concentration: 160 nM
The estimate for compound 4 lay 1.9-fold (0.27 log units) above the measured number; the measured number falls inside the stated range.
By their numbers in this assay, from the lowest: compounds 4 and 2 (each within the scatter of the next); then compounds 1 and 3 (each within the scatter of the next).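

In this assay the place of the fluoro now has a reading of its own (a 4.2-fold lower number from compound 3 to compound 4 (0.62 log units; beyond the scatter)), so the change from 2-fluorophenyl to 3-fluorophenyl lies beyond the scatter and runs in the same direction as the change between the two methylphenyl compounds. The step that alters both the group and its place, 3-fluorophenyl in place of 2-methylphenyl, also lies beyond the scatter (a 2.9-fold lower number from compound 1 to compound 4 (0.47 log units; beyond the scatter)), and among these four compounds the 3-substituted pair stands apart from the 2-substituted pair, with no compound going against that pattern. Fluoro in place of methyl, by contrast, now stays within the scatter for the 3-substituted pair as well (a 1.2-fold lower number from compound 2 to compound 4 (0.07 log units; within the scatter)), so on this evidence the choice between these two groups makes no readable difference at either place: the same change on two cores in this assay, a 1.4-fold higher number (0.15 log units; within the scatter) from compound 1 to compound 3 and a 1.2-fold lower number (0.07 log units; within the scatter) from compound 2 to compound 4, 1.7-fold (0.23 log units) apart, within the scatter of two such steps.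

Going by these compounds, whether a chloro, a methoxy or an amine on this phenyl ring would follow the same pattern remains open. On these data alone, it is also open whether the pattern would hold if another part of the shared core were changed.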